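Taking the methoxybenzyl off the indole nitrogen

This account rests on a few compounds, and the source may have more. Where it says the series, first, only, none or still open, it means among the compounds named here.

Compound 1 `COc1ccc2[nH]cc(/C=C(\C#N)C(=O)c3c[nH]c4ccc(OC)cc34)c2c1`: > 50000 nM
Compound 2 `COc1ccc(Cn2cc(/C=C(\C#N)C(=O)c3c[nH]c4cc(OC)ccc34)c3ccccc32)cc1`: > 50000 nM
Compound 3 `N#C/C(=C\c1c[nH]c2cc(F)ccc12)C(=O)c1c[nH]c2cc(F)ccc12`: > 50000 nM

In a functional assay on PC-3 cells (Homo sapiens) for cytotoxicity, read by WST assay, with a stated time of 48 h (a lower number here means a stronger inhibitor, a higher number a weaker inhibitor), compound 1 gives > 50000 nM, which is a limit of the assay and not a number. Compound 2 gives > 50000 nM, again a limit. Compound 3 gives > 50000 nM, a limit as well. For the measured compounds named here, compound 2 thus stands at the limit of > 50000 nM in this assay, at which 3 of the 3 values shown sit; no compound here gives a measured number.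

Compound 4 `COc1ccc2c(C(=O)/C(C#N)=C/c3c[nH]c4ccccc34)c[nH]c2c1` differs from compound 2 by hydrogen in place of 4-methoxybenzyl on an aromatic nitrogen. No step between measured compounds is shown, so the size of this change cannot be read from a measured pair. Compound 1 and compound 3 already carry a hydrogen on that nitrogen and both sit at the limit, so no step beyond the scatter is expected.

Compound 4 is therefore expected to give about 60000 nM, with a range from 20000 nM to 200000 nM. This corresponds to an expected step that the limit leaves unreadable from compound 2 to compound 4.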

Compound 4, half-maximal inhibitory concentration: 12000 nM
Compound 4: middle estimate off by 5.0-fold (0.70 log units), on the high side; measured number outside the range, below it.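

In this assay, replacing 4-methoxybenzyl with hydrogen on the aromatic nitrogen gives an at least 4.1-fold lower number from compound 2 to compound 4 (0.61 log units; beyond the scatter). For the compounds shown here, this shows that a change at this position can move the result, and compound 4 is the only compound here with a measured number rather than a limit. The true size of the step remains unknown because the value for compound 2 is a limit: the limit of > 50000 nM in this assay, at which 3 of the 4 values shown sit.

As far as these compounds go, it remains open whether a methyl group on that nitrogen would stay close to hydrogen or move toward 4-methoxybenzyl. From the compounds shown here alone, the effect of a longer chain ending in an amine is also open.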